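The source may hold more compounds than are shown below. What is called first, only, known or untested is meant among the compounds shown, and "the series" means these compounds.

Measured compounds:
compound 1 `CCCCCCCC/C=C\CCCCCCCC(=O)OC[C@@H](C)OP(=O)(O)OC[C@H](N)C(=O)O` — 12.4%
compound 2 `CCCCCCCC/C=C\CCCCCCCC(=O)OC[C@H](COC)OP(=O)(O)OC[C@H](N)C(=O)O` — "not active" (no number reported)
compound 3 `CCCCCCCCCCCOc1ccccc1CCC(=O)O[C@@H]1CCOC[C@@H]1OP(=O)(O)OC[C@H](N)C(=O)O` — 19.3%

In an assay on HEK293 cells for agonist activity at putative P2Y purinoceptor 10 (Mus musculus), with a stated time of 1 h (a higher number here means a larger maximal response, a lower number a smaller maximal response), compound 3 gives 19.3%, the highest of the two numbers reported. Compound 1 gives 12.4%, which lies within the scatter of compound 3, so the two cannot be ranked. Compound 2 is reported in this assay as "not active" (no number reported), without a number. Compound 4 `CCCCCCCCCCCOc1ccccc1CCC(=O)O[C@H]1CCOC[C@@H]1OP(=O)(O)OC[C@H](N)C(=O)O` is still to be measured. It differs from compound 3 in one place: the two compounds have the same atoms and bonds; at least one stereo element is drawn with a configuration in one of them and without one in the other: 1 of 4 stereo elements differ; a stereocentre at a saturated ring carbon is drawn R in compound 3 and S in compound 4. For the measured compounds named here, no step between two measured compounds covers such a change, so nothing here shows how large its effect might be. A shift either way in this assay is possible; a small loss is expected, of about a number 5.3 percentage points lower from compound 3 to compound 4 (within the scatter), which stays within the scatter. Compound 4 is expected to give 14%, between 2% and 28%.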

Compound 4, largest response reached (Emax), in percent of the reference or control that the assay uses: 11.1%
Compound 4: middle estimate off by 2.9 percentage points, on the high side; measured number inside the range.
By their numbers in this assay, from the lowest: compounds 4, 1 and 3 (each within the scatter of the next).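

In this assay, for the compounds shown here, changing a stereocentre at a saturated ring carbon from R to S gives a number 8.2 percentage points lower from compound 3 to compound 4 (within the scatter), the first measured step for this kind of change here. This single pair therefore shows no effect of the change that can be told apart from the scatter. One point limits the comparison: the fact that one of compounds 3 and 4 is drawn with a defined configuration and the other without, at the place where they differ.

The compounds shown leave open whether this stereocentre would matter in a compound with a larger maximal response. Also open, as far as these compounds go, is whether an amide in place of the ester would change the response.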